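The source may hold more compounds than are shown below. What is called first, only, known or untested is meant among the compounds shown, and "the series" means these compounds.

Working notes on the series, the step from compound 1 to compound 4.

Compound 1 `CCOC(=O)C(=O)Nc1cccccc1=O` is the parent of the series. In a functional assay on the whole organism (strain Sprague-Dawley CD) for inhibition, with Rattus norvegicus as the target, read by paw edema, at a dose of 10 mg/kg by the intraperitoneal route (a higher number here means a stronger effect of the compound at the dose given, a lower number a weaker effect), compound 1 gives 80%, the highest of the three numbers measured; its nearest neighbour is compound 2 `CCOC(=O)C(=O)Nc1ccccc(C)c1=O`, which gives 40%, and the furthest is compound 3 `CCOC(=O)C(=O)Nc1ccccc(OC)c1=O`, which gives 24%. Both measured steps from the parent go downward: a number 40 percentage points lower from compound 1 to compound 2 (beyond the scatter) and a number 56 percentage points lower from compound 1 to compound 3 (beyond the scatter), while between the two substituted compounds a number 16 percentage points lower from compound 2 to compound 3 (beyond the scatter) is a smaller change. All three measured steps alter the aromatic carbon of the shared core and leave the remainder of the molecule untouched.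

Compound 4 `O=C(Nc1cccccc1=O)C(=O)Oc1ccccc1` differs from compound 1 as follows: phenyl in place of ethyl on an oxygen next to a carbonyl group. Among the compounds with values here, none of the measured steps changes anything on the oxygen next to the carbonyl group, so there is no direct precedent in this set for the size or direction of the step in this assay. Within the data shown here, the only guidance is that compound 1 stands at the top and that every change measured so far has moved the number downward, so a step down rather than up is the more cautious expectation, of moderate size, a number 20 percentage points lower from compound 1 to compound 4 (beyond the scatter). For compound 4 the expected value in this assay is 60%, within a range from 25% to 90%.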

Compound 4, a percentage reported as inhibition, in the whole organism at one dose (the size of the read-out at that dose, not a potency): 68%
Compound 4: the middle estimate sits 8 percentage points below what was measured; measured number inside the range.
By their numbers in this assay, from the lowest: compound 3; then compound 2; then compound 4; then compound 1.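

Within the data shown here, the first change on the oxygen next to a carbonyl group, phenyl in place of ethyl, gives a number 12 percentage points lower from compound 1 to compound 4 (beyond the scatter) in this assay. This position therefore accepts a much larger group, one six-membered aromatic ring of carbon only with 6 heavy atoms in place of 2, at a modest cost, whereas the two changes on the aromatic carbon of compound 1 are large steps, a number 40 percentage points lower from compound 1 to compound 2 (beyond the scatter) and a number 56 percentage points lower from compound 1 to compound 3 (beyond the scatter); the step remains beyond the scatter, so ethyl still gives the higher number of this pair. Nothing available bears on why the number falls with this change.

The compounds shown leave open how the number behaves with other groups on this oxygen, such as methyl, benzyl, a longer chain, or the hydrogen of the free carboxylic acid, so one step cannot yet show a trend with the size of the group or whether the aromatic ring itself matters. They also leave open whether methyl or methoxy on the aromatic carbon lowers the number to the same extent when phenyl stands in place of ethyl.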